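This account rests on a few compounds, and the source may have more. Where it says the series, first, only, none or still open, it means among the compounds named here.

Of the compounds shown here, three sharing one core have been measured in an assay on HeLa cells for inhibition of Kinesin-like protein KIF15 (Homo sapiens), read by microscopy, with stated times of 2 s and 20 s, tested at 750 nM; a higher number here means more inhibition at the concentration tested (going by the name of the read-out), a lower number less inhibition. Compound 1, `O=C1Nc2ccc(C(=O)c3ccco3)cc2/C1=C/c1cc(Cl)c(O)c(Br)c1`, gives 62%, the highest of the three numbers. Compound 2, `O=C1Nc2ccc(C(=O)c3ccco3)cc2/C1=C/c1cc(Br)cc(Br)c1`, gives 16%, and compound 3, `O=C1Nc2ccc(C(=O)c3ccco3)cc2/C1=C/c1ccc(O)c(Br)c1`, gives 23%. Both steps away from compound 1 fall beyond the scatter: a number 46 percentage points lower from compound 1 to compound 2 (beyond the scatter) and a number 39 percentage points lower from compound 1 to compound 3 (beyond the scatter). A third step, a number 7 percentage points higher from compound 2 to compound 3 (within the scatter), stays within the scatter, so those two numbers cannot be ordered against each other.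

Compound 4, `O=C1Nc2ccc(C(=O)c3ccco3)cc2/C1=C/c1ccncc1`, has not yet been measured. Its change from compound 1 is a group of 6 heavy atoms (5 carbon, 1 nitrogen; one six-membered aromatic ring with 1 hetero atom) in place of a group of 9 heavy atoms (6 carbon, 1 oxygen, 1 chlorine, 1 bromine; one six-membered aromatic ring of carbon only), on a double-bonded chain carbon bound to a double-bonded ring carbon. The group that leaves carries the hydrogen-bond donor, the oxygen, the chlorine and the bromine; what enters is one six-membered aromatic ring with 1 hetero atom and no hydrogen-bond donor. Among the compounds with values here, the steps that bear on this are the two from compound 1: removing the chloro alone already cost a large amount, and exchanging the whole ring for one without the oxygen cost still more. A large drop is therefore expected for compound 4, the step being a number 47 percentage points lower from compound 1 to compound 4 (beyond the scatter). Compound 4 is estimated at 15%, within a range from 0% to 35%.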

Compound 4, a percentage reported as inhibition, at one concentration (the size of the read-out at that concentration, not a potency): 0.8%
Beside the measured number, compound 4's estimate is 14.2 percentage points above it, within the range that was stated.
By their numbers in this assay, from the lowest: compound 4; then compounds 2 and 3 (each within the scatter of the next); then compound 1.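

Measured in this assay, pyridin-4-yl on this double-bonded chain carbon gives the lowest number of the series, since a number 61.2 percentage points lower from compound 1 to compound 4 (beyond the scatter), a number 22.2 percentage points lower from compound 3 to compound 4 (beyond the scatter) and a number 15.2 percentage points lower from compound 2 to compound 4 (beyond the scatter) are all beyond the scatter. Compounds 2 and 3, whose numbers could not be ordered against each other, therefore did not mark the bottom of the range at this place, and a ring carrying no bromine, chlorine or oxygen reads lower still, though each of these steps changes several things at once and so cannot be pinned on one atom. No measurement available here explains why the number falls this far.

On these data alone, whether a plain phenyl group on this carbon would read like compound 4 remains open, and with it how much of the step belongs to the ring nitrogen rather than to the groups that left. Also open, as far as these compounds go, is whether a pyridine ring carrying the hydroxyl, chloro and bromo groups of compound 1 would regain the higher number, and whether an amine or a carboxylic acid could stand in for the hydroxyl.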